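The compounds below may be only part of what the source reports. "The series", "measured", "known", "first", "only" and "open" are said of these compounds alone.

Compound 1 `Cc1cc(CCC#N)cc(C)c1Oc1cc(Nc2ccc(C#N)cc2)c(N)cc1C(=O)N(C)C` was examined in an ADME assay on TZM cells (Homo sapiens) for cytotoxicity, with a stated time of 1 days; a lower number here means that less compound is tolerated, a higher number that more compound is tolerated. In this assay compound 1 gives 38200 nM. Of the two numbers available, compound 1 has the lowest; its nearest neighbour is compound 2 `Cc1cc(CCC#N)cc(C)c1Oc1cc(Nc2ccc(C#N)cc2)c(N)cc1C(=O)NC1CC1`, which in this assay gives 121000 nM, while a further entry, compound 3 `Cc1cc(CCC#N)cc(C)c1Oc1cc(Nc2ccc(C#N)cc2)c(N)cc1CN1CCN(C)CC1`, has no single number in this assay, where compound 3 is recorded as "not determined" (no result reported). Among the compounds with values here, the one measured step that changes a single place is a 3.2-fold higher number from compound 1 to compound 2 (0.50 log units; beyond the scatter), with cyclopropylamino in place of dimethylamino on a carbonyl carbon.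

Compound 4 `Cc1cc(CCC#N)cc(C)c1Oc1ccc(N)c(Nc2ccc(C#N)cc2)c1` differs from compound 1 by hydrogen in place of dimethylcarbamoyl on an aromatic carbon. Within the data shown here, the step from compound 1 to compound 2 altered the same dimethylcarbamoyl group rather than removing it, so it bears on the present change only loosely, and no measured pair shows the loss of the whole group. Because a 3.2-fold higher number from compound 1 to compound 2 (0.50 log units; beyond the scatter) shows that reworking this group shifts the number beyond the scatter, a shift of similar size is plausible here too, though its direction is not fixed by the data. For compound 4 a step of a 1.3-fold higher number from compound 1 to compound 4 (0.12 log units; within the scatter) is therefore expected. Compound 4 is estimated at 50000 nM, with a range from 15000 nM to 170000 nM.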

Compound 4, half-maximal cytotoxic concentration: > 200000 nM
Compound 4: only a limit was reported; the forecaster's own chance of this, stated with the estimate: 15%; middle value at least 4.0-fold (0.60 log units) away from the limit.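

Compound 4 carries only a limit rather than a single number: the limit of > 200000 nM in this assay, at which 1 of the 4 values shown sits.

Even so, this settles what the earlier compounds left unanswered: they only reworked the amide on this aromatic carbon, whereas removing the whole dimethylcarbamoyl group and leaving hydrogen gives an at least 5.2-fold higher number from compound 1 to compound 4 (0.71 log units; beyond the scatter), so the direction of this change is now clear and the shift lies beyond the scatter. Measured against the cyclopropylcarbamoyl group, the same replacement by hydrogen gives an at least 1.6-fold higher number from compound 2 to compound 4 (0.21 log units; that floor lies within the scatter), and because only a floor is known, this comparison does not establish a real difference, although the true gap could be larger.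

Going by these compounds, what stays open is how far the number for compound 4 really lies beyond its limit, and whether the rise depends on losing the carbonyl or on losing the whole group. Compound 3 has no reported result, so the data give no reading for a carbon-linked amine at this position, and a carboxylic acid or a simple methyl group there remains an open comparison.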